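A Hydroxylated Pyrrolidine Arm in Place of the Piperidine Chain

The source may hold more compounds than are shown below. What is called first, only, known or untested is meant among the compounds shown, and "the series" means these compounds.

Compound 1 `CCCCCCCCCCc1ccc(-c2noc(CN)n2)cc1` gives 62% in an assay on HeLa cells for inhibition of sphingosine-1-phosphate transporter SPNS2 (Mus musculus), read by LC-MS, tested at 2 uM; on this read-out higher numbers stand for more inhibition at the one concentration tested (going by the name of the read-out) and lower numbers for less inhibition. Among the compounds with values here, compound 2 `CCCCCCCCCCc1ccc(-c2noc(CCCN3CCCCC3)n2)cc1` gives 0% in this assay, and the single measured step, a number 62 percentage points lower from compound 1 to compound 2 (beyond the scatter), is the only one in this set. On these two numbers compound 2 stands lowest, with compound 1 the nearest and higher by that same large step.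

Compound 3 `CCCCCCCCCCc1ccc(-c2noc(CC(O)CN3CCCC3)n2)cc1` has not yet been measured in this assay. Its difference from compound 2 is 1-hydroxy-2-(pyrrolidin-1-yl)ethyl in place of 2-(piperidin-1-yl)ethyl on a saturated chain carbon bound to an aromatic carbon. Within the data shown here, the one step that bears on this change is the large drop a number 62 percentage points lower from compound 1 to compound 2 (beyond the scatter), which shows that exchanging the amino group of compound 1 for a ring-bearing chain removed the inhibition entirely. Compound 3 keeps a ring-bearing chain on that carbon rather than returning to the amino group, so only a small step is expected in this assay, at most a modest rise from the floor that compound 2 sits on.

Compound 3 is therefore estimated at 10%, within 0% to 40%, an expected step of a number 10 percentage points higher from compound 2 to compound 3 (within the scatter).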

Compound 3, a percentage reported as inhibition, at one concentration (the size of the read-out at that concentration, not a potency): 21%
Compound 3: middle estimate off by 11 percentage points, on the low side, within the range that was stated.
By their numbers in this assay, from the lowest: compound 2; then compound 3; then compound 1.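

In this assay a ring-bearing chain on this saturated chain carbon does not have to abolish inhibition: 1-hydroxy-2-(pyrrolidin-1-yl)ethyl in place of 2-(piperidin-1-yl)ethyl gives a number 21 percentage points higher from compound 2 to compound 3 (beyond the scatter) and so lifts the read-out off the floor on which compound 2 sits. This arm still falls well short of the amino group, since 1-hydroxy-2-(pyrrolidin-1-yl)ethyl in place of amino gives a number 41 percentage points lower from compound 1 to compound 3 (beyond the scatter) and leaves compound 1 the highest of the three. No measurement shown here explains either step.

Two things change together between compound 2 and compound 3, the six-membered ring giving way to a five-membered ring and a hydroxy group entering, and the compounds shown do not separate them; a 3-(pyrrolidin-1-yl)propyl chain or a 2-hydroxy-3-(piperidin-1-yl)propyl chain would do so. Also open, on these data alone, is how much of the level of compound 1 depends on the amine standing so close to the core, which a longer chain such as 3-aminopropyl would address.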